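Acetyl replaced by tetrafluoroethoxy on a shared core

The source may report more compounds than this note shows. Statements on the series, on what has been measured and on what is new or still open speak of the compounds shown alone.

Two compounds share the same core and differ only in the group attached to the outer benzene ring. Compound 1 `CCCCOc1ccc(Nc2nc3nonc3nc2O)cc1` carries a butoxy chain and in an assay on mitochondria from L6 cells (Rattus norvegicus) for activation, with a stated time of 90 min (on this read-out higher numbers stand for an effect only at larger amounts of compound and lower numbers for an effect already at smaller amounts), gives 3700 nM. Compound 2 `CC(=O)c1ccc(Nc2nc3nonc3nc2O)cc1` carries an acetyl group instead and in this assay gives 93700 nM, the highest of the two numbers. Within the data shown here, the step of a 25-fold higher number from compound 1 to compound 2 (1.40 log units; beyond the scatter) is the only measured step and it is large. Compound 3 `Oc1nc2nonc2nc1Nc1ccc(OC(F)(F)C(F)F)cc1` is not yet measured; it differs from compound 2 by 1,1,2,2-tetrafluoroethoxy in place of acetyl on an aromatic carbon. The entering group, like the butoxy of compound 1, is joined to the ring through oxygen, and the acetyl that raised the number in the measured step leaves. A step back toward the number of compound 1 is therefore expected, estimated as a 16-fold lower number from compound 2 to compound 3 (1.19 log units; beyond the scatter). Compound 3 is expected to give about 6000 nM, within 1500 nM to 25000 nM.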

Compound 3, half-maximal effective concentration: 7000 nM
The estimate for compound 3 lay 1.2-fold (0.07 log units) below the measured number, within the range that was stated.
By their numbers in this assay, from the lowest: compounds 1 and 3 (each within the scatter of the next); then compound 2.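

In this assay, 1,1,2,2-tetrafluoroethoxy in place of acetyl gives a 13-fold lower number from compound 2 to compound 3 (1.13 log units; beyond the scatter) and so shows that a second group joined through oxygen at this position also stands well apart from the acetyl of compound 2. Replacing butyl on that oxygen with 1,1,2,2-tetrafluoroethyl gives a 1.9-fold higher number from compound 1 to compound 3 (0.28 log units; within the scatter) and so shows that these two different chains, one with fluorine and one without, cannot be told apart in this read-out. No measurement at hand explains either step.

From the compounds shown here alone, it remains open whether a methoxy group or a longer alkoxy chain would also match compound 1 and compound 3. Going by these compounds, it is equally open whether an amine or a carboxylic acid at this position would read like these two oxygen-linked groups or like the acetyl.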